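A few compounds are considered here, and "the series" means these few. Any claim that something is new, unique, unknown or untested is made for them only; others in the source may bear on it.

Measured compounds: compound 1 `O=C(CN(c1nc(Cl)nc2[nH]cnc12)C1CC1)N[C@@H](CC(=O)OCc1ccccc1)C(=O)OCc1ccccc1` gives 12.1%; compound 2 `CC(C)[C@H](NC(=O)CN(c1ncnc2c1ncn2C1CCCCO1)C1CC1)C(=O)OCc1ccccc1` gives 25.8%; compound 3 `O=C(CN(c1nc(Cl)nc2[nH]cnc12)C1CC1)NCC(=O)OCc1ccccc1` gives 21.7%.

In a functional assay on the whole organism (Tail, strain ICR) with Mus musculus as the target, in the tail flick test, with a stated time of 120 min, at a dose of 25 umol/kg by the oral route (a lower number here means a weaker effect, a higher number a stronger effect of the compound at the dose given), compound 3 stands second highest of the three numbers, yet its nearest neighbour is compound 2, and the two values lie within the scatter of each other, as do those of compound 3 and compound 1. Going by the values given here, the one measured step that bears on the new compound is a number 9.6 percentage points higher from compound 1 to compound 3 (within the scatter), a change at the same chain carbon that compound 4 now alters. Compound 4 `C[C@@H](O)[C@H](NC(=O)CN(c1nc(Cl)nc2[nH]cnc12)C1CC1)C(=O)OCc1ccccc1` differs from compound 3 by 1-hydroxyethyl in place of hydrogen on a saturated chain carbon bound to an amide-type nitrogen and a carbonyl carbon. Since the step from compound 1 to compound 3 stayed within the scatter, and compound 2, which also carries a side chain on that carbon, gives 25.8% on a different core, no step beyond the scatter is expected in this assay in either direction. Compound 4 is therefore estimated at 22%, with a range from 8% to 38%, meaning an expected step of a number 0.3 percentage points higher from compound 3 to compound 4 (within the scatter).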

Compound 4, a percentage reported as activity, at one dose (the size of the read-out at that dose, not a potency): 30.7%
Compound 4: the middle estimate sits 8.7 percentage points below what was measured; the measured number falls inside the stated range.
By their numbers in this assay, from the lowest: compounds 1, 3, 2 and 4 (each within the scatter of the next, the first and the last beyond it).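

In this assay, 1-hydroxyethyl in place of hydrogen on the saturated chain carbon bound to an amide-type nitrogen and a carbonyl carbon gives a number 9 percentage points higher from compound 3 to compound 4 (within the scatter) and so cannot be told apart from hydrogen there. Set against (benzyloxycarbonyl)methyl at the same carbon, the same group gives a number 18.6 percentage points higher from compound 1 to compound 4 (beyond the scatter) and is the first step at this position to pass beyond the scatter, which shows that the two side chains can be told apart in this read-out even though neither can be told apart from hydrogen. Nothing available explains this difference.

From the compounds shown here alone, whether an amine, a carboxylic acid or a longer chain on this carbon would move the read-out remains open. So does the part played by the hydroxyl of 1-hydroxyethyl, which a plain ethyl group at the same carbon would address.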